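This account rests on a few compounds, and the source may have more. Where it says the series, first, only, none or still open, it means among the compounds named here.

Three compounds have been measured in an ADME assay; on this read-out lower numbers stand for a shorter-lived compound and higher numbers for a longer-lived compound:

Compound 1 `COc1ccc(C[S+]([O-])c2ncccc2C(=O)Nc2ccncc2)c(OC)c1C` gives 11.6 h.
Compound 2 `COc1ccc(C[S+]([O-])c2ncccc2C(=O)Nc2ccncc2)c(OC)c1OC` gives 116 h.
Compound 3 `COc1cc(OC)c(C[S+]([O-])c2ncccc2C(=O)Nc2ccncc2)c(OC)c1` gives only a limit of the assay, < 0.03 h.

Compound 1 and compound 2 share a core, and the only difference between them is methyl in place of methoxy on an aromatic carbon. That change made a step of a 10-fold lower number from compound 2 to compound 1 (1.00 log units; beyond the scatter). Compound 3 is built from the same atoms as compound 2, joined differently; the difference between the two cores is not broken down here. Compound 3 sits at the limit of < 0.03 h in this assay, at which 1 of the 3 values shown sits, so for it only a limit is known, not a number.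

Compound 4 `COc1cc(C)c(C[S+]([O-])c2ncccc2C(=O)Nc2ccncc2)c(OC)c1` has not yet been measured in this assay. It differs from compound 3 by methyl in place of methoxy on an aromatic carbon. Among the measured compounds shown here, this is the same kind of change as the one from compound 2 to compound 1, but not the same: in compound 1 the methyl stands ortho to two methoxy groups and meta to a large group, whereas in compound 4 it stands ortho to a large group and meta to two methoxy groups.

From compound 3 to compound 4 a step that the limit leaves unreadable from compound 3 to compound 4 is expected. This expectation rests on the step of a 10-fold lower number from compound 2 to compound 1 (1.00 log units; beyond the scatter), which lowered the number, and on compound 3 already standing at a limit rather than a number. Compound 4 is therefore expected to give 0.02 h, between 0.003 h and 0.5 h, and most likely the assay will again report only a limit for it.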

Compound 4, half-life: 0.09 h
The estimate for compound 4 lay 4.5-fold (0.65 log units) below the measured number; the range from low to high includes it.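

Replacing methoxy with methyl on an aromatic carbon gave an at least 3.0-fold higher number from compound 3 to compound 4 (0.47 log units; beyond the scatter) in this assay. Set beside the same replacement on the other core, this shows that the change does not carry over from one core to the other in this series, not even in direction: the same change on two cores in this assay, a 10-fold lower number (1.00 log units; beyond the scatter) from compound 2 to compound 1 and an at least 3.0-fold higher number (0.47 log units; beyond the scatter) from compound 3 to compound 4, at least 30-fold (1.47 log units) apart, beyond the scatter of two such steps

Compound 3 gives < 0.03 h, a limit of the assay and not a number, so the exact size of the new step stays unknown, and these two cores give neither a reason for the reversal nor a rule for any further core.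

The compounds shown leave open whether the reversal belongs to methyl alone or would also appear with another group on the same carbon, such as an ethyl group or a chlorine atom. They also leave open what the same replacement would do at either of the two methoxy groups that remain in compound 4, and whether a third core would follow compound 1 and compound 2 or compound 3 and compound 4.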